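Swapping Fluoro for Tert-Butyl: From Compound 3 to Compound 4

The source may report more compounds than this note shows. Statements on the series, on what has been measured and on what is new or still open speak of the compounds shown alone.

Three carboxylic acids have been measured so far in an assay on cells for inhibition of Palmitoleoyl-protein carboxylesterase NOTUM variant C330S (Homo sapiens), read by fluorescence, with a stated time of 40 min; a lower number here means a stronger inhibitor, a higher number a weaker inhibitor. Compound 1 `O=C(O)C1CCN(c2ccccc2F)C1` gives 11000 nM in this assay. Compound 2 `Cc1c(C(=O)O)ccn1-c1ccccc1` gives 3800 nM. Compound 3 `Cc1cc(C(=O)O)c(C)n1-c1cccc(F)c1` gives 1500 nM, the lowest number of the three and therefore the strongest inhibitor of this small set: its gap to compound 2 and its larger gap to compound 1 both lie beyond the usual scatter of repeated measurements.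

Compound 4 `Cc1cc(C(=O)O)c(C)n1-c1cccc(C(C)(C)C)c1` has not yet been measured. It keeps the shared core of compound 3 unchanged and differs in a single place: tert-butyl in place of fluoro on an aromatic carbon. A small halogen goes out and a branched alkyl group comes in, on the same aromatic carbon, meta to a large group.

For the measured compounds named here, no pair among the measured compounds shows an exchange of this kind, so its effect cannot be read off from earlier steps. Because compound 3 already sits at 1500 nM, the expectation is a moderate move toward a lower number rather than a dramatic one, a step estimated as a 2.5-fold lower number from compound 3 to compound 4 (0.40 log units; beyond the scatter), though a result within the scatter would not be surprising. Compound 4 is expected to give about 600 nM in this assay, with a likely range from 150 nM to 2500 nM.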

Compound 4, half-maximal inhibitory concentration: 460 nM
For compound 4 the middle estimate is 1.3-fold (0.12 log units) above the measured one; low and high end bracket the measured number.
By their numbers in this assay, from the lowest: compound 4; then compound 3; then compound 2; then compound 1.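

For the compounds shown here, on this aromatic carbon, meta to a large group, the exchange can now be read for the first time: in this assay, tert-butyl in place of fluoro gives a 3.3-fold lower number from compound 3 to compound 4 (0.51 log units; beyond the scatter). The position therefore takes a much larger, branched alkyl group, and the number falls rather than rises, so a substituent here can do more than leave the inhibition unchanged. Compound 4 now has the lowest number of the four acids, although this rests on a single modest step between two compounds. No measured evidence bears on why the number falls.

On these data alone, with only fluoro and tert-butyl compared at this position, it remains open whether a smaller branched group such as isopropyl would give part of the same change, or whether a trifluoromethyl or methoxy group, of similar reach but different atoms, would follow it. Going by these compounds alone, it also remains open whether tert-butyl would give a comparable step on another carbon of the same aromatic ring, or on a different core from the one shared by compound 3 and compound 4.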